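A few compounds are considered here, and "the series" means these few. Any claim that something is new, unique, unknown or untested is made for them only; others in the source may bear on it.

Working notes on the hydrazone series.

Compound 1 `CC1CCC(=NNc2ccccc2)c2ncc(C(=O)O)c(=O)n21` gives 1.2 umol/kg in a functional assay on the whole organism with Rattus norvegicus as the target (a lower number here means that less compound is needed, a higher number that more compound is needed for the effect), and stands lowest of the two numbers measured in this assay. Compound 3 `Cc1cc(C)c(NN=C2CCC(C)n3c2ncc(C(=O)O)c3=O)c(C)c1` gives 320 umol/kg in this assay; no single-step comparison between compound 1 and compound 3 is computed here, but the trimethyl-substituted aryl of compound 3 goes with the far higher number of the two. Compound 2 `CC1CCC(=NNc2ccccc2)c2ncc(C(=O)NO)c(=O)n21` gives > 100 umol/kg in this assay, which is a limit and not a number. Among the compounds with values here, the one measured step, an at least 83-fold higher number from compound 1 to compound 2 (1.92 log units; beyond the scatter), concerns hydroxyamino in place of hydroxy on a carbonyl carbon and runs into (the limit of > 100 umol/kg in this assay, at which 1 of the 3 values shown sits).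

Compound 4 `CC1CCC(=NNc2ccc(Cl)cc2Cl)c2ncc(C(=O)O)c(=O)n21` is not yet measured. It differs from compound 1 as follows: 2,4-dichlorophenyl in place of phenyl on an amine nitrogen. Within the data shown here, no measured step touches this aryl position, so the step from compound 1 to compound 2 does not bear on it, and the only guide is the pair of values for compound 1 and compound 3, where a substituted aryl goes with a higher number. A step in the same direction, though smaller, is therefore expected, a 6.7-fold higher number from compound 1 to compound 4 (0.82 log units; beyond the scatter). Compound 4 is expected to give 8 umol/kg in this assay, within a range from 1.5 umol/kg to 50 umol/kg.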

Compound 4, dose for 50% inhibition: > 100 umol/kg
Compound 4: no number, only a limit (the forecaster's own chance of this, stated with the estimate: 10%); at least 12-fold (1.09 log units) between middle value and limit.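

In this assay the aryl on the amine nitrogen now has a measured step of its own: with the carboxylic acid and the rest of the core of compound 1 kept, 2,4-dichlorophenyl in place of phenyl gives an at least 83-fold higher number from compound 1 to compound 4 (1.92 log units; beyond the scatter). Compound 4 gives > 100 umol/kg, which is a limit and not a number, so the step shows only a minimum size: the limit of > 100 umol/kg in this assay, at which 2 of the 4 values shown sit. Within the data shown here, until now only the change on the carbonyl carbon had a measured step, so this is the first single change showing that the low number of compound 1 also depends on the aryl alone.

The compounds shown leave open whether a phenyl carrying a single chlorine, or one carrying a fluorine or a methoxy group, stays close to compound 1 or also reaches the limit. Also open are the true size of the step and whether either chlorine alone would be enough, since no compound with only one of the two is among those shown.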